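Chain length at the acid of the cyclohexylphenyl series

This account rests on a few compounds, and the source may have more. Where it says the series, first, only, none or still open, it means among the compounds named here.

Measured so far:
compound 1 `Cc1cc(CC(=O)O)ccc1-c1noc(-c2ccc(C3CCCCC3)cc2)n1` — 4000 nM
compound 2 `Cc1cc(CCC(=O)O)ccc1-c1noc(-c2ccc(OC(C(F)(F)F)C(F)(F)F)c(C#N)c2)n1` — 0.7 nM

In a functional assay on CHO cells for agonist activity at sphingosine 1-phosphate receptor 5 (Homo sapiens), read by GTPgammaS binding (on this read-out lower numbers stand for an effect already at smaller amounts and higher numbers for an effect only at larger amounts of compound), compound 1 gives 4000 nM, the higher of the two numbers recorded. Compound 2 gives 0.7 nM in this assay, and the gap between the two lies beyond the scatter; the two compounds differ at the acid chain and at the tail of the shared core, so no single step can be read from them.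

Compound 3 `Cc1cc(CCCCCC(=O)O)ccc1-c1noc(-c2ccc(C3CCCCC3)cc2)n1` keeps the core and tail of compound 1 and carries 4-carboxybutyl in place of carboxy on a saturated chain carbon bound to an aromatic carbon. For the measured compounds named here, no measured pair shows this change, so the expectation rests on compound 1 alone. A step from compound 1 to compound 3 of a 1.3-fold lower number from compound 1 to compound 3 (0.12 log units; within the scatter) in this assay is expected, with a wide range in either direction. Compound 3 is estimated at 3000 nM in this assay, between 400 nM and 20000 nM.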

Compound 3, half-maximal effective concentration: 1080 nM
Beside the measured number, compound 3's estimate is 2.8-fold (0.44 log units) above it; the range from low to high includes it.
By their numbers in this assay, from the lowest: compound 2; then compound 3; then compound 1.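

In this assay, for the compounds shown here, 4-carboxybutyl in place of carboxy on a saturated chain carbon bound to an aromatic carbon gives a 3.7-fold lower number from compound 1 to compound 3 (0.57 log units; beyond the scatter), the first step that can be read at a single place. Going by these compounds alone, the position therefore tolerates the longer chain with the tail of compound 1 held fixed, and the number does not rise; with only two chain lengths compared, this fixes a direction for this pair and no trend with length. Nothing at hand accounts for the step.

As far as these compounds go, whether the change runs evenly with length remains open, as a 2-carboxyethyl or 3-carboxypropyl chain on this tail would show. Also open, from the compounds shown here alone, is whether the carboxylic acid itself is needed at the chain end, or whether an amine or an amide could stand there.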